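Trading trifluoromethylphenyl for pyridinyl: cytotoxicity expectation

The source may report more compounds than this note shows. Statements on the series, on what has been measured and on what is new or still open speak of the compounds shown alone.

Compound 1 `Cc1cc(C#N)cc(C)c1Oc1nc(Nc2ccc(C#N)cc2)ncc1-c1cccc2ccccc12` reached only the assay limit, > 267000 nM, in an ADME assay on MT4 cells (Homo sapiens) for cytotoxicity, read by MTT assay, with a stated time of 5 days; on this read-out lower numbers stand for higher toxicity in this test and higher numbers for lower toxicity in this test. Compound 2 `Cc1cc(C#N)cc(C)c1Oc1nc(Nc2ccc(C#N)cc2)ncc1-c1ccc(N)cc1` gives 310 nM. Compound 3 `Cc1cc(C#N)cc(C)c1Oc1nc(Nc2ccc(C#N)cc2)ncc1-c1ccc(C(F)(F)F)cc1` gives 35000 nM.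

Compound 3 holds the highest of the two numbers; its nearest neighbour is compound 2, separated by a 110-fold higher number from compound 2 to compound 3 (2.05 log units; beyond the scatter). Compound 1 sits at a limit (the limit of > 267000 nM in this assay, at which 1 of the 3 values shown sits), which also makes an at least 7.6-fold lower number from compound 1 to compound 3 (0.88 log units; beyond the scatter) a lower bound only. Compound 4 `Cc1cc(C#N)cc(C)c1Oc1nc(Nc2ccc(C#N)cc2)ncc1-c1ccncc1` differs by pyridin-4-yl in place of 4-(trifluoromethyl)phenyl on an aromatic carbon. Going by the values given here, no measured step involves pyridin-4-yl, so the bearing of the two known steps is indirect: the large step from amino to trifluoromethyl shows this position can move the read-out strongly. A modest decrease is expected, a 2.3-fold lower number from compound 3 to compound 4 (0.37 log units; beyond the scatter), giving an estimate for compound 4 of 15000 nM, ranging from 3000 nM to 80000 nM.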

Compound 4, half-maximal cytotoxic concentration: 28000 nM
Beside the measured number, compound 4's estimate is 1.9-fold (0.27 log units) below it, within the range that was stated.
By their numbers in this assay, from the lowest: compound 2; then compounds 4 and 3 (each within the scatter of the next). At a limit, above all of these: compound 1.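

In this assay, pyridin-4-yl and 4-(trifluoromethyl)phenyl cannot be told apart at this position, since the swap gives a 1.3-fold lower number from compound 3 to compound 4 (0.10 log units; within the scatter). The new group also stands well clear of 4-aminophenyl, with a 90-fold higher number from compound 2 to compound 4 (1.96 log units; beyond the scatter), so among these compounds only compound 2 reaches such a low number. Compound 1 gives only a limit, so an at least 9.5-fold lower number from compound 1 to compound 4 (0.97 log units; beyond the scatter) is a lower bound: the limit of > 267000 nM in this assay, at which 1 of the 4 values shown sits.

Still open, going by these compounds, is how a 4-hydroxyphenyl, a 4-(dimethylamino)phenyl or a pyridin-3-yl group would read here. These would help show whether the free amine itself sets compound 2 apart.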